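Aryl ether in place of thiophene on the pendant ring

This account rests on a few compounds, and the source may have more. Where it says the series, first, only, none or still open, it means among the compounds named here.

Compound 2 `Cc1ccccc1-n1nc(C)c2c1NC(=O)[C@H](C)S[C@@H]2c1ccc(-c2ccsc2)cc1` gives 1400 nM in an assay on isolated protein for agonist activity at Bile acid receptor (Homo sapiens), read by AlphaScreen, with a stated time of 30 min (on this read-out lower numbers stand for an effect already at smaller amounts and higher numbers for an effect only at larger amounts of compound), the lowest of the two numbers on hand. Compound 1 `COc1ccccc1-n1nc(C)c2c1NC(=O)[C@H](C)S[C@@H]2c1ccc(Oc2ccccc2)cc1`, which carries a phenoxy group on the same ring and a methoxy group on its N-aryl ring, gives 3300 nM in this assay; it differs from compound 2 in two places, so no single step can be read between them. Compound 3 `COc1ccccc1Oc1ccc([C@H]2S[C@@H](C)C(=O)Nc3c2c(C)nn3-c2ccccc2C)cc1` is not yet measured. It keeps everything else of compound 2 and changes one group: 2-methoxyphenoxy in place of thiophen-3-yl on an aromatic carbon. Among the measured compounds shown here, no measured pair isolates this change. Compound 1 serves as the nearest guide, since its aryl ether gives 3300 nM. The step from compound 2 to compound 3 is expected to go upward, modestly beyond the scatter, by a 1.9-fold higher number from compound 2 to compound 3 (0.29 log units; within the scatter). Compound 3 is estimated at 2700 nM, with a range from 900 nM to 8000 nM.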

Compound 3, half-maximal effective concentration: 1700 nM
Compound 3: middle estimate off by 1.6-fold (0.20 log units), on the high side; low and high end bracket the measured number.
By their numbers in this assay, from the lowest: compounds 2, 3 and 1 (each within the scatter of the next, the first and the last beyond it).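

In this assay, 2-methoxyphenoxy in place of thiophen-3-yl, on an aromatic carbon para to a large group, gives a 1.2-fold higher number from compound 2 to compound 3 (0.08 log units; within the scatter), so the numbers of the two compounds cannot be told apart. Among the compounds shown here, this is the first step that isolates this position, and 9 heavy atoms enter there where 5 leave without a shift beyond the scatter. Nothing on hand bears on the reason for this result.

Compound 1 differs from each of compound 2 and compound 3 in two places, so those steps cannot be read, and the separate contributions of the phenoxy group and the methoxy group on the N-aryl ring stay unresolved. Also open, from the compounds shown here alone, is how a carboxylic acid or a morpholine would read at this position on the same core.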